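A few compounds are considered here, and "the series" means these few. Any claim that something is new, unique, unknown or untested is made for them only; others in the source may bear on it.

Two compounds of this series carry measurements in a functional assay on A549 cells (Homo sapiens) for inhibition, read by MTT assay, with a stated time of 72 h; a lower number here means a stronger inhibitor, a higher number a weaker inhibitor. Compound 1 `CN(C(=O)NC(=O)c1ccc(F)c(F)c1)c1nc(C(F)(F)F)c(C(=O)N/N=C/c2ccccc2C(F)(F)F)s1` gives 6.96 ug/mL. Compound 2 `CN(C(=O)NC(=O)c1ccc(F)c(F)c1)c1nc(C(F)(F)F)c(C(=O)N/N=C/c2cccc(C(F)(F)F)c2)s1` gives 6.52 ug/mL. Within the data shown here, the one measured step, a 1.1-fold lower number from compound 1 to compound 2 (0.03 log units; within the scatter), moves the trifluoromethyl group around the aromatic ring and leaves the number essentially unchanged. Compound 2 thus holds the lowest of the two numbers, but its gap to compound 1 is within the scatter, so no order between them can be stated.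

Compound 3 `CN(C(=O)NC(=O)c1ccc(F)c(F)c1)c1nc(C(F)(F)F)c(C(=O)N/N=C/c2ccc([N+](=O)[O-])cc2)s1` is the next member. Relative to compound 2 the change is 4-nitrophenyl in place of 3-(trifluoromethyl)phenyl on a carbon with a double bond to nitrogen. Among the measured compounds shown here, no measured step in this assay bears directly on an exchange of the trifluoromethyl group for a nitro group; the only step available concerns the position of the same group and was within the scatter. With nothing pointing either way, the expectation for compound 3 is no step beyond the scatter, a 1.0-fold lower number from compound 2 to compound 3 (0.00 log units; within the scatter), giving an estimated 6.5 ug/mL with a range from 3 ug/mL to 14 ug/mL.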

Compound 3, half-maximal inhibitory concentration: 5.78 ug/mL
For compound 3 the middle estimate is 1.1-fold (0.05 log units) above the measured one; the range from low to high includes it.
By their numbers in this assay, from the lowest: compounds 3, 2 and 1 (each within the scatter of the next).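

In this assay, the place on the carbon with a double bond to nitrogen now shows more than a shift of one group around the phenyl ring: a different group, 4-nitrophenyl, gives a 1.1-fold lower number from compound 2 to compound 3 (0.05 log units; within the scatter) and a 1.2-fold lower number from compound 1 to compound 3 (0.08 log units; within the scatter). The three compounds therefore show no separation here, even though 4-nitrophenyl brings hydrogen-bond acceptors that neither trifluoromethyl-bearing phenyl group has. No available data explain this flat picture.

From the compounds shown here alone, it remains open whether an amine or a carboxylic acid on the phenyl ring, or a longer chain in place of the ring, would move the number beyond the scatter. Going by these compounds, it is also open whether the same flat picture would hold with changes elsewhere on the shared core.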